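This account rests on a few compounds, and the source may have more. Where it says the series, first, only, none or still open, it means among the compounds named here.

Measured compounds:
- compound 1, `c1ccc(-c2ccc(CCc3nc(CC4CCCC4)c[nH]3)cc2)nc1`: 22 nM
- compound 2, `CCC(C)(C)Cc1c[nH]c(CCc2ccc(-c3csnn3)cc2)n1`: 11 nM
- compound 3, `CCC(C)(C)Cc1c[nH]c(CCc2ccc(-c3cccnc3)cc2)n1`: 4.3 nM

All three were tested in a functional assay on HEK293 cells for agonist activity at Bombesin receptor subtype-3 (Mus musculus), read by luminescence and calcium flux, with a stated time of 10 min; on this read-out lower numbers stand for an effect already at smaller amounts and higher numbers for an effect only at larger amounts of compound. Compound 3 gives the lowest of the three numbers: its nearest neighbour is compound 2 with 11 nM, and compound 1 lies furthest away with 22 nM, both beyond the scatter.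

The next compound, compound 4 with the structure `CCC(C)(C)Cc1c[nH]c(CCc2ccc(-c3cccc(C#N)n3)cc2)n1`, differs from compound 3 in one place: 6-cyanopyridin-2-yl in place of pyridin-3-yl on an aromatic carbon.

Among the compounds with values here, only one measured step bears on this change. Between compound 2 and compound 3 the aromatic ring at the same place was exchanged, and the result was a 2.6-fold lower number from compound 2 to compound 3 (0.41 log units; beyond the scatter). That step shows that swapping one small heterocycle for another at this position moves the number only modestly. Within the data shown here, no compound carrying a nitrile or a six-membered ring joined through the carbon next to its nitrogen has been measured, so there is no direct precedent for compound 4.

Given that the one comparable exchange moved the number by a modest amount, compound 4 is expected to stay in the same region as compound 3, with a slight loss more likely than a gain; the expected step is a 2.1-fold higher number from compound 3 to compound 4 (0.32 log units; beyond the scatter). For compound 4 the estimate is therefore 9 nM, within a range from 3 nM to 30 nM.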

Compound 4, half-maximal effective concentration: 26 nM
Compound 4: the middle estimate sits 2.9-fold (0.46 log units) below what was measured, within the range that was stated.
By their numbers in this assay, from the lowest: compound 3; then compounds 2, 1 and 4 (each within the scatter of the next, the first and the last beyond it).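

In this assay, the exchange at this place gives a 6.0-fold higher number from compound 3 to compound 4 (0.78 log units; beyond the scatter). This runs in the opposite direction to the earlier ring exchange, which gave a 2.6-fold lower number from compound 2 to compound 3 (0.41 log units; beyond the scatter), so the ring on this aromatic carbon can move the number either way, and a larger ring with a nitrile does not bring a gain here. The 6-cyanopyridin-2-yl group also compares poorly with the smaller 1,2,3-thiadiazol-4-yl group, with a 2.4-fold higher number from compound 2 to compound 4 (0.37 log units; beyond the scatter), which leaves pyridin-3-yl with the lowest number of the three rings tried on this shared core, and no measurement at hand explains the rise.

Two things change at once in this exchange: the pyridine ring is joined through a different carbon, and a nitrile enters, and the compounds shown do not separate the two. Also open, on these data alone, is how a pyridin-3-yl ring would read in this assay if it carried a nitrile, a methoxy group or an amine, which would show whether a group on the ring or the way the ring is joined matters more.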